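The compounds below may be only part of what the source reports. "The series", "measured", "known", "first", "only" and "open" are said of these compounds alone.

Compound 1 `COc1ccc(F)cc1CNCCCNc1ccnc2cc(CC(C)C)ccc12` gives 9.47 in a physicochemical assay for acid dissociation.
Compound 2 `COc1ccc(F)cc1CNCCCNc1ccnc2cc(Cc3ccc(F)cc3Cl)ccc12` gives 9.47 in this assay.
Compound 3 `COc1ccc(F)cc1CNCCCNc1ccnc2cc(-c3ccc(F)cc3)ccc12` gives 9.47 in this assay.

Compound 3 stands level with compounds 1 and 2: the step of no change at the digits printed from compound 1 to compound 3 (within the scatter) and the step of no change at the digits printed from compound 2 to compound 3 (within the scatter) both lie within the scatter, as does the step of no change at the digits printed from compound 1 to compound 2 (within the scatter). The three compounds thus share one value of this assay although they carry different groups on the shared core.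

Compound 4 `COc1ccc(F)cc1CNCCCNc1ccnc2cc(-c3ccc(C(F)(F)F)cc3)ccc12` differs from compound 3 by trifluoromethyl in place of fluoro on an aromatic carbon. Going by the values given here, no measured step changes this exact group, but the steps of no change at the digits printed from compound 1 to compound 3 (within the scatter) and no change at the digits printed from compound 2 to compound 3 (within the scatter) exchange groups at the same region of the core without any shift in this assay, and the present change is again one on the far side of the core from the amines. Compound 4 is therefore expected to show no step beyond the scatter, with no change at the digits printed from compound 3 to compound 4 (within the scatter). The estimate for compound 4 in this assay is 9.47, expected to lie between 9.2 and 9.75.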

Compound 4, acid dissociation constant: 9.47
Compound 4: the middle estimate sits on the measured number at the digits printed, within the range that was stated.
By their numbers in this assay, from the lowest: compounds 1, 2, 3 and 4 (each within the scatter of the next).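

In this assay, trifluoromethyl in place of fluoro, on an aromatic carbon para to a large group, gives no change at the digits printed from compound 3 to compound 4 (within the scatter) and is the first exchange shown at this carbon, where the earlier steps replaced the whole group on the shared core. The wider comparisons read the same way, with no change at the digits printed from compound 2 to compound 4 (within the scatter) and with no change at the digits printed from compound 1 to compound 4 (within the scatter) as well, so all four compounds now share one value. No measurement given here accounts for this result.

Open, as far as these compounds go, is whether an amine or a carboxylic acid at this same carbon would also leave the value where it stands. Equally open, from the compounds shown here alone, is whether an amide in place of the amine in the chain of the shared core would do so.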